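The source may hold more compounds than are shown below. What is called first, only, known or untested is meant among the compounds shown, and "the series" means these compounds.

Three related compounds have been tested in a functional assay on A549 cells (Homo sapiens) for inhibition, read by MTT assay, with a stated time of 24 h; on this read-out lower numbers stand for stronger inhibition and higher numbers for weaker inhibition. Going by the values given here, compound 1 `C/C=C(\C)C(=O)O[C@H]1[C@]2(C)C[C@@H]3O[C@@]1(O)C=C1C4=CC(=O)O[C@@H](c5ccoc5)[C@]4(C)CC[C@@H]1[C@]3(C)[C@@H]2C(=O)C(=O)OC` gives 44400 nM, the only true number among them. Compound 2 `C/C=C(\C)C(=O)O[C@@H]1[C@]2(OC(=O)C3CC3)C=C3C4=CC(=O)O[C@@H](c5ccoc5)[C@]4(C)CC[C@@H]3[C@@]3(C)[C@H](C[C@]1(C)[C@H]3[C@@H](OC(=O)C1CC1)C(=O)OC)O2` reads > 100000 nM, which is a limit of the assay and not a number. Compound 3 `C/C=C(\C)C(=O)O[C@@H]1[C@]2(OC(=O)CC)C=C3C4=CC(=O)O[C@@H](c5ccoc5)[C@]4(C)CC[C@@H]3[C@@]3(C)[C@H](C[C@]1(C)[C@H]3[C@@H](OC(=O)CC)C(=O)OC)O2` reads > 100000 nM, which is also a limit. No two of these compounds differ in just one place, so no measured step is available as a guide.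

Compound 4 `C/C=C(\C)C(=O)O[C@H]1[C@]2(C)C[C@@H]3O[C@@]1(O)C=C1C4=CC(=O)O[C@@H](c5ccoc5)[C@]4(C)CC[C@@H]1[C@]3(C)[C@@H]2[C@@H](OC(C)=O)C(=O)OC` departs from compound 1 on a saturated ring carbon, where acetoxy(methoxycarbonyl)methyl takes the place of (methoxycarbonyl)carbonyl: acetoxy(methoxycarbonyl)methyl in place of (methoxycarbonyl)carbonyl on a saturated ring carbon. Starting from compound 1 at 44400 nM, a modest weakening is expected in this assay, with a real chance that the reading reaches (the limit of > 100000 nM in this assay, at which 2 of the 3 values shown sit). The expected change is a 1.4-fold higher number from compound 1 to compound 4 (0.13 log units; within the scatter). For compound 4 the estimated value is 60000 nM, with an expected range of 25000 nM to 100000 nM.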

Compound 4, half-maximal inhibitory concentration: > 100000 nM
Compound 4 ended at the assay's limit; the forecaster's own chance of this, stated with the estimate: 35%; middle value at least 1.6-fold (0.22 log units) from the limit.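

Going by these compounds alone, the earlier compounds offered no measured step, so this is the first sign that this saturated ring carbon responds to a change of group: in this assay, acetoxy(methoxycarbonyl)methyl in place of (methoxycarbonyl)carbonyl gives an at least 2.2-fold higher number from compound 1 to compound 4 (0.35 log units; beyond the scatter). Compound 4 reads > 100000 nM, which is a limit and not a number. Compound 1 therefore remains the only compound shown with a true number in this assay, and the other readings gather at the top of the scale: the limit of > 100000 nM in this assay, at which 3 of the 4 values shown sit.

As far as these compounds go, how far the step runs beyond its printed size stays open. Also open, from the compounds shown here alone, is whether another group on this carbon, such as a hydroxyl with the methyl ester kept, or a free carboxylic acid in place of that ester, would give a true number.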